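The source may hold more compounds than are shown below. What is called first, only, known or untested is meant among the compounds shown, and "the series" means these compounds.

Measured in a functional assay on MIA PaCa-2 cells (Homo sapiens) for inhibition, read by MTT assay, with a stated time of 7 days; on this read-out higher numbers stand for weaker inhibition and lower numbers for stronger inhibition:
- compound 1 `CCN(CC)S(=O)(=O)c1ccc(S(=O)(=O)N2CCC[C@@H](C(=O)N[C@H]3CC[C@H](OC)CC3)C2)cc1`: 1350 nM
- compound 2 `CCN(CC)S(=O)(=O)c1ccc(S(=O)(=O)N2CCC[C@@H](C(=O)N3CCOCC3)C2)cc1`: 350 nM
- compound 3 `CCN(CC)C(=O)c1ccc(S(=O)(=O)N2CCC[C@@H](C(=O)N3CCC(F)(F)CC3)C2)cc1`: 70 nM

Compound 2 holds the second highest of these three numbers, with compound 1 higher and compound 3 lower. Compound 4 `CCN(CC)S(=O)(=O)c1ccc(S(=O)(=O)N2CCC[C@@H](C(=O)N[C@H]3CC[C@@H](OC)CC3)C2)cc1` departs from compound 2 as follows: (4-methoxycyclohexyl)amino in place of morpholin-4-yl on a carbonyl carbon. In words, (4-methoxycyclohexyl)amino replaces morpholin-4-yl on a carbonyl carbon. Within the data shown here, one measured step bears on this change, the modest 3.9-fold lower number from compound 1 to compound 2 (0.59 log units; beyond the scatter), which is beyond the scatter. Compound 1 carries the entering group but differs from compound 4 in its stereochemistry, so a similar step in the reverse direction, towards a higher number, is expected in this assay. The expected change is a 2.9-fold higher number from compound 2 to compound 4 (0.46 log units; beyond the scatter). Compound 4 is estimated at 1000 nM, with an expected range of 350 nM to 3000 nM.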

Compound 4, half-maximal inhibitory concentration: 960 nM
Estimate against measurement, compound 4: 1.0-fold (0.02 log units) above; measured number inside the range.
By their numbers in this assay, from the lowest: compound 3; then compound 2; then compounds 4 and 1 (each within the scatter of the next).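

In this assay, the cost of this change on the carbonyl carbon holds for a second drawn configuration of the (4-methoxycyclohexyl)amino group: a 2.7-fold higher number from compound 2 to compound 4 (0.44 log units; beyond the scatter). The configuration of that group makes no difference beyond the scatter here: a 1.4-fold lower number from compound 1 to compound 4 (0.15 log units; within the scatter). That comparison isolates configuration alone: the fact that compounds 1 and 4 differ only in the configuration as drawn.

From the compounds shown here alone, it remains open whether the methoxy group matters at all, and a plain cyclohexylamino group or a hydroxyl in place of the methoxy would test this. Compound 3 differs from the others in more than one place, so the contribution of each of its changes cannot be read.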